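The source may report more compounds than this note shows. Statements on the series, on what has been measured and on what is new or still open speak of the compounds shown alone.

In an assay for inhibition of Indoleamine 2,3-dioxygenase 1 (Homo sapiens), with stated times of 10 min and 60 min (a lower number here means a stronger inhibitor, a higher number a weaker inhibitor), compound 1 `Nc1cccc(CNc2cc(C(F)(F)F)cc3[nH]ncc23)c1` gives > 100000 nM, which is a limit of the assay rather than a measured number. Compound 2 `NCCn1ncc2c(NCc3ccccc3[N+](=O)[O-])cc(C(F)(F)F)cc21` gives > 100000 nM in this assay, again a limit. For the measured compounds named here, compound 3 `O=[N+]([O-])c1ccccc1CNc1cc(Br)cc2[nH]ncc12` is the single compound here with a number, 8040 nM in this assay. Compound 1 therefore sits at the weak edge of what the set shows, namely (the limit of > 100000 nM in this assay, at which 2 of the 3 values shown sit). Compound 4 `FC(F)(F)c1cc(NCc2cccc(Br)c2)c2cn[nH]c2c1` differs from compound 1 by bromo in place of amino on an aromatic carbon. Going by the values given here, no measured pair of compounds carries this change, so its size is not known from the data. Compound 4 is expected to move into the measurable range by a step of an at least 2.5-fold lower number from compound 1 to compound 4 (0.39 log units; beyond the scatter) in this assay. The estimate for compound 4 is 40000 nM, expected to fall between 8000 nM and 150000 nM.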

Compound 4, half-maximal inhibitory concentration: > 100000 nM
Compound 4: a limit, no number; the forecaster's own chance of this, stated with the estimate: 45%; middle value at least 2.5-fold (0.39 log units) away from the limit.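

Compound 4 gives > 100000 nM in this assay, which is a limit. For the compounds shown here, with compound 1 also at a limit, no step between compound 1 and compound 4 can be read. The compounds shown leave open whether bromo in place of amino changes inhibition at all.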